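The source may hold more compounds than are shown below. What is called first, only, known or untested is meant among the compounds shown, and "the series" means these compounds.

Working notes on the series, read in a functional assay on HeLa cells (Homo sapiens) for inhibition, read by MTT assay, with a stated time of 48 h; on this read-out lower numbers stand for stronger inhibition and higher numbers for weaker inhibition:
- compound 1 `O=C(CC(c1ccc(Cl)cc1)C(C(=O)Nc1ccccn1)C(=O)Nc1ccccn1)c1ccccc1` gives 13600 nM
- compound 2 `O=C(CC(c1ccccc1)C(C(=O)Nc1ccccn1)C(=O)Nc1ccccn1)c1ccc(F)cc1` gives "not active" (no number reported)
- compound 3 `O=C(CC(c1ccc(Cl)cc1)C(C(=O)Nc1ccccn1)C(=O)Nc1ccccn1)c1ccc(F)cc1` gives 4100 nM
- compound 4 `O=C(CC(c1ccc([N+](=O)[O-])cc1)C(C(=O)Nc1ccccn1)C(=O)Nc1ccccn1)c1ccccc1` is not yet measured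

Compound 1 gives 13600 nM, the higher of the two numbers in this assay. Compound 3 lies lower, and compound 2 has no number.

The next change leads to compound 4: nitro in place of chloro on an aromatic carbon. In words, this is nitro in place of chloro on an aromatic carbon.

Within the data shown here, no measured step covers this replacement. The only one, a 3.3-fold lower number from compound 1 to compound 3 (0.52 log units; beyond the scatter), is modest and beyond the scatter, but it is fluoro in place of hydrogen on an aromatic carbon, a different change at a different place. Compound 2, without the chloro, gives "not active" (no number reported), while compound 3 gives 4100 nM. This shows that a number cannot be taken for granted in this series.

With no basis for a direction, no step beyond the scatter is expected, and the uncertainty stays wide. The expected change is a 1.2-fold lower number from compound 1 to compound 4 (0.09 log units; within the scatter). For compound 4 the estimated value is 11000 nM, with an expected range from 3500 nM to 35000 nM.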

Compound 4, half-maximal inhibitory concentration: 30000 nM
For compound 4 the middle estimate is 2.7-fold (0.44 log units) below the measured one; low and high end bracket the measured number.
By their numbers in this assay, from the lowest: compound 3; then compound 1; then compound 4.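

The first replacement read at this position, 4-chlorophenyl to 4-nitrophenyl, gives a 2.2-fold higher number from compound 1 to compound 4 (0.34 log units; beyond the scatter) in this assay and so moves the number upward. The position therefore responds to an exchange of one substituent for another, and the chloro of compound 1 gives the lower number of this pair, though the step is modest. Nothing measured here explains the direction of this step.

The compounds shown carry only chloro, nitro or, in compound 2, hydrogen at this position, so it remains open whether a trend in substituents exists there at all. As far as these compounds go, an amine or a methoxy group at the same place could test this, and the effect of nitro alongside the fluoro of compound 3 also remains open.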